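The compounds below may be only part of what the source reports. "The series", "measured", "known", "first", "only" and "open" are said of these compounds alone.

Measured so far:
- compound 1 `CCOc1ccc(C2CC2C(=O)NNC(=O)c2ccncc2)cc1` gives 43000 nM in a functional assay on A549 cells (Homo sapiens) for inhibition, read by MTT assay, with a stated time of 72 h; on this read-out lower numbers stand for stronger inhibition and higher numbers for weaker inhibition
- compound 2 `O=C(NNc1nncc2ccccc12)C1CC1c1ccc(OCC(F)(F)F)cc1` gives 48000 nM in this assay

Compound 1 has the lowest of the two numbers, but its gap to compound 2 lies within the scatter, so neither can be ranked above the other; both sit at the weak end of the range in this assay.

Compound 3 `O=C(NNC(=O)C1CC1c1ccc(OCC(F)(F)F)cc1)c1ccncc1` differs from compound 1 by trifluoromethyl in place of methyl on a saturated chain carbon bound to an oxygen on an aromatic ring. Among the compounds with values here, no pair of measured compounds covers this change on the shared core. Compound 2 carries the 2,2,2-trifluoroethoxy group on another core, and in this assay compound 2 gives 48000 nM, which stays within the scatter of compound 1. On that basis no step beyond the scatter is expected from compound 1 to compound 3, a 1.0-fold higher number from compound 1 to compound 3 (0.02 log units; within the scatter), in this assay. Compound 3 is estimated at 45000 nM, with a range from 15000 nM to 130000 nM.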

Compound 3, half-maximal inhibitory concentration: 10000 nM
Estimate against measurement, compound 3: 4.5-fold (0.65 log units) above, outside the stated range (below it).
By their numbers in this assay, from the lowest: compound 3; then compounds 1 and 2 (each within the scatter of the next).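

In this assay, replacing ethoxy with 2,2,2-trifluoroethoxy on the shared core gives a 4.3-fold lower number from compound 1 to compound 3 (0.63 log units; beyond the scatter), a modest step beyond the scatter. Within the data shown here, this is the first reading of trifluoromethyl in place of methyl at this position with the rest of the structure held constant, and it shows that the position responds to this change. Compound 2 carries the same group on another core but has no partner on that core, so it could not show this, and nothing available here bears on the reason for the step.

Still open, from the compounds shown here alone, is whether the step carries over to the core of compound 2. Also open, going by these compounds, is how this position responds to a partly fluorinated group such as 2,2-difluoroethoxy, or to a longer chain such as propoxy.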